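Methoxy to hydrogen on two cores

The source may report more compounds than this note shows. Statements on the series, on what has been measured and on what is new or still open speak of the compounds shown alone.

Compound 1 `COc1cc(/C=N/N2C(=O)CSC2=S)cc(OC)c1O` and compound 3 `COc1cc(/C=N/N2C(=O)CSC2=S)ccc1O` share one core; compound 2 `COc1cc(/C=N/NC(=O)c2ccncc2)cc(O)c1O` and the unmeasured compound 4 `O=C(N/N=C/c1ccc(O)c(O)c1)c1ccncc1` share another. The difference between the two cores is not broken down here. In a physicochemical assay, read by spectrophotometry (a higher number here means a weaker inhibitor, a lower number a stronger inhibitor), compound 1 gives 11800 nM, compound 3 gives 12900 nM and compound 2 gives 18400 nM; all three lie within the scatter of one another, so no order among them is claimed.

The change from compound 1 to compound 3 is hydrogen in place of methoxy on an aromatic carbon and made a step of a 1.1-fold higher number from compound 1 to compound 3 (0.04 log units; within the scatter). The change from compound 2 to compound 4 is hydrogen in place of methoxy on an aromatic carbon; it is the same kind of change, the place differing in that it is meta to a hydroxy group and meta to a large group rather than meta to a group of 9 heavy atoms and meta to a methoxy group. This change occurs twice among the compounds shown, once measured.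

For the measured compounds named here, for compound 4 the step in this assay is expected to be a 1.1-fold higher number from compound 2 to compound 4 (0.04 log units; within the scatter), beside the measured 1.1-fold higher number from compound 1 to compound 3 (0.04 log units; within the scatter), resting on the single earlier step being within the scatter and on compound 2 at 18400 nM. Compound 4 is therefore estimated at 20000 nM, expected to fall between 10000 nM and 40000 nM.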

Compound 4, half-maximal inhibitory concentration: 6100 nM
Beside the measured number, compound 4's estimate is 3.3-fold (0.52 log units) above it; the measured number lies below the stated range.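

In this assay the replacement of methoxy by hydrogen made a step of a 3.0-fold lower number from compound 2 to compound 4 (0.48 log units; beyond the scatter), whereas on the other core the same kind of change made a step of a 1.1-fold higher number from compound 1 to compound 3 (0.04 log units; within the scatter), so the near-absence of a step did not carry over between these two cores. This rests on one pair for each core and sets no rule for either, and the two pairs differ in more than the core, since the change in compound 2 sits meta to a hydroxy group, a surrounding that the pair of compound 1 and compound 3 does not share. Nothing shown bears on why the two steps differ.

No pair shown separates the part played by the core from that of the hydroxy group, so it remains open which of them goes with the larger step. Also open, on these data alone, is what an amine or an ethoxy group in the same place on the core of compound 2 would give in this assay.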